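Methyl in place of bromo: compound 3 to compound 4

The compounds below may be only part of what the source reports. "The series", "measured", "known", "first", "only" and "open" are said of these compounds alone.

Compound 3 `O=C(/C=C/c1ccc(Br)cc1)Nc1ccc2ncnc(Nc3cccc(Cl)c3)c2c1` gives 1.86 ug/mL in a functional assay on A549 cells (Homo sapiens) for antiproliferative activity, read by MTT assay, with a stated time of 48 h (on this read-out higher numbers stand for weaker inhibition and lower numbers for stronger inhibition), the lowest of the three numbers seen so far; compound 2 `COc1ccc(/C=C/C(=O)Nc2ccc3ncnc(Nc4cccc(Br)c4)c3c2)cc1` at 3.36 ug/mL lies within the scatter of it, while compound 1 `O=C(/C=C/c1ccc(Br)cc1)Nc1ccc2ncnc(Nc3cccc(Br)c3)c2c1` at 15.3 ug/mL lies further off. Compound 4 `Cc1ccc(/C=C/C(=O)Nc2ccc3ncnc(Nc4cccc(Cl)c4)c3c2)cc1` is compound 3 with methyl in place of bromo on an aromatic carbon. Going by the values given here, the one measured step at the same place is a 4.6-fold lower number from compound 1 to compound 2 (0.66 log units; beyond the scatter); the step of an 8.2-fold lower number from compound 1 to compound 3 (0.92 log units; beyond the scatter) sits elsewhere in the molecule and bears only loosely. Among the compounds with values here, the single exchange of bromo at this place lowered the number, so a smaller lowering, uncertain in size, is expected here. Compound 4 is therefore estimated at 1.2 ug/mL, with a range of 0.4 ug/mL to 3.5 ug/mL, an expected step of a 1.6-fold lower number from compound 3 to compound 4 (0.19 log units; within the scatter).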

Compound 4, half-maximal inhibitory concentration: 6.03 ug/mL
Beside the measured number, compound 4's estimate is 5.0-fold (0.70 log units) below it; measured number outside the range, above it.
By their numbers in this assay, from the lowest: compounds 3, 2 and 4 (each within the scatter of the next, the first and the last beyond it); then compound 1.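

Going by these compounds alone, at this place, para to a large group, losing bromo no longer lowers the number: methyl gives a 3.2-fold higher number from compound 3 to compound 4 (0.51 log units; beyond the scatter) and methoxy gave a 4.6-fold lower number from compound 1 to compound 2 (0.66 log units; beyond the scatter) in the only other step here, so exchanging bromo has no single direction. These two steps differ in the entering group and in the halogen elsewhere in the molecule, and the compounds shown do not separate the two. Nothing measured accounts for the rise.

Still open, as far as these compounds go, is whether methyl raises the number when the other halogen is bromo, and how an amine or a carboxylic acid at this place would read.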